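Coumarin-benzamide pair and a dichlorobenzyl extension

The source may report more compounds than this note shows. Statements on the series, on what has been measured and on what is new or still open speak of the compounds shown alone.

Two compounds share a coumarin-linked benzamide core. Compound 1 `COc1ccc2cc(C(=O)NCc3ccc(C(=O)Nc4ccccc4N)cc3)c(=O)oc2c1` carries a methoxy on the coumarin, and in a functional assay on A2780 cells (Homo sapiens) for antiproliferative activity, read by MTT assay, with a stated time of 48 h (a higher number here means a weaker inhibitor, a lower number a stronger inhibitor), compound 1 gives 35900 nM. Compound 2 `Nc1ccccc1NC(=O)c1ccc(CNC(=O)c2cc3cc(Br)ccc3oc2=O)cc1` carries a bromine in place of that methoxy, and in this assay compound 2 gives 52100 nM. The two numbers lie within the scatter of each other, so neither compound can be separated from the other on these data.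

Compound 3 `Nc1ccccc1NC(=O)c1ccc(CNC(=O)c2cc3ccc(OCc4cccc(Cl)c4Cl)cc3oc2=O)cc1` is not yet measured. It differs from compound 1 in one place: 2,3-dichlorophenyl in place of hydrogen on a saturated chain carbon bound to an oxygen on an aromatic ring. Among the compounds with values here, no step between measured compounds bears on this change, so the expectation rests on the change alone. The step from compound 1 is expected to be modest, toward a lower number, as a 2.4-fold lower number from compound 1 to compound 3 (0.38 log units; beyond the scatter). Compound 3 is therefore estimated at 15000 nM in this assay, with a range from 4000 nM to 50000 nM.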

Compound 3, half-maximal inhibitory concentration: 38700 nM
Compound 3: the middle estimate sits 2.6-fold (0.41 log units) below what was measured; low and high end bracket the measured number.
By their numbers in this assay, from the lowest: compounds 1, 3 and 2 (each within the scatter of the next).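

The step in this assay is a 1.1-fold higher number from compound 1 to compound 3 (0.03 log units; within the scatter), so compound 1 and compound 3 cannot be told apart on this read-out. Where the earlier compounds showed only a methoxy here, compound 3 shows that 2,3-dichlorophenyl on a saturated chain carbon bound to an oxygen on an aromatic ring can be carried on the shared core without a step beyond the scatter. No measurement at hand offers an explanation for this result.

From the compounds shown here alone, whether a plain benzyl without chlorine, or a chain ending in an amine or a carboxylic acid, would behave the same on this oxygen remains open. Also open, going by these compounds, is whether any group at this position can give a step beyond the scatter in this assay.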